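The source may hold more compounds than are shown below. What is called first, only, known or untested is meant among the compounds shown, and "the series" means these compounds.

Measured so far:
compound 1 `NCc1cn(-c2ccccc2)nn1` gives 970 nM
compound 2 `NCc1cn(-c2cccc(C(=O)O)c2)nn1` gives 50700 nM

Working notes on the series. Compound 1 is the lowest of the two numbers in an assay on isolated protein for inhibition of Amine oxidase [flavin-containing] A (Homo sapiens), read by fluorescence; on this read-out lower numbers stand for stronger inhibition and higher numbers for weaker inhibition; its nearest neighbour is compound 2, reached by a 52-fold higher number from compound 1 to compound 2 (1.72 log units; beyond the scatter), a change of carboxy in place of hydrogen on an aromatic carbon.

Compound 3 `NCc1cn(-c2ccc(C(=O)O)cc2)nn1` is not yet measured. It differs from compound 1 by carboxy in place of hydrogen on an aromatic carbon. Among the measured compounds shown here, the only measured step bearing on this change is the one from compound 1 to compound 2, which also introduces a carboxy group in place of hydrogen on the same six-membered aromatic ring, at a different position, and it was large and beyond the scatter. On that basis a carboxy group entering the ring of compound 1 is expected to raise the number in this assay again, by a step of comparable size, though with a single precedent the size is uncertain. The estimate for compound 3 in this assay is therefore 20000 nM, with a range from 3000 nM to 100000 nM, corresponding to an expected step of a 21-fold higher number from compound 1 to compound 3 (1.31 log units; beyond the scatter).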

Compound 3, half-maximal inhibitory concentration: 19600 nM
Compound 3: the middle estimate sits 1.0-fold (0.01 log units) above what was measured, within the range that was stated.
By their numbers in this assay, from the lowest: compound 1; then compound 3; then compound 2.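

With the carboxy group on the aromatic carbon para to a group of 7 heavy atoms, this assay shows a 20-fold higher number from compound 1 to compound 3 (1.31 log units; beyond the scatter), so the rise seen with compound 2 is not confined to a single place on the ring. At its different position on the same ring, the carboxy group of compound 2 gives 50700 nM and the carboxy group of compound 3 gives 19600 nM, the lower of these two printed values, while both stand well above the value of compound 1. Nothing measured here gives a reason for the rise at either position

A methyl ester, a primary amide or a hydroxymethyl group on the same aromatic carbon would show whether the rise belongs to the carboxy group alone or follows any group placed there. Equally open are how a carboxylic acid on a longer chain from that carbon would compare and what a change to the aminomethyl group of the shared core would do to the number in this assay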